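Chloro on the Pendant Phenyl Ring: An Unresolved Step

This account rests on a few compounds, and the source may have more. Where it says the series, first, only, none or still open, it means among the compounds named here.

Compound 1, with structure `CCOC(=O)C(=O)CC(=O)/C=C/c1cn(-c2ccccc2)c2ccccc12`, carries an ethyl ester on the diketo chain. In an assay on isolated protein for inhibition of DNA nucleotidylexotransferase (Homo sapiens), read by scintillation counting, with a stated time of 10 min (on this read-out higher numbers stand for weaker inhibition and lower numbers for stronger inhibition), compound 1 gives > 40 uM, which is a limit of the assay and not a number. Compound 2, with structure `CCOC(=O)C(=O)CC(=O)/C=C/c1cn(-c2ccc(Cl)cc2)c2ccccc12`, is its relative in which the change is chloro in place of hydrogen on an aromatic carbon. In this assay compound 2 gives > 40 uM, again a limit and not a number. The step that the two limits leave unreadable from compound 1 to compound 2 therefore cannot be read, because the limit of > 40 uM in this assay, at which 2 of the 3 values shown sit, catches both ends of it.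

Compound 3, with structure `O=C(/C=C/c1cn(Cc2ccccc2)c2ccccc12)CC(=O)C(=O)O`, belongs to a different core; how that core differs from the core of compound 1 is not broken down here. In this assay, for the measured compounds named here, compound 3 gives 7.9 uM, the only numerical value among the three measured compounds.

Compound 4, with structure `O=C(/C=C/c1cn(Cc2ccc(Cl)cc2)c2ccccc12)CC(=O)C(=O)O`, is still to be measured. It differs from compound 3 by chloro in place of hydrogen on an aromatic carbon, the same change that separates compound 1 from compound 2, here cut one bond further out as benzyl to 4-chlorobenzyl. Going by the values given here, since the earlier step is not readable, there is no measured precedent for its size, and the step of a 1.0-fold higher number from compound 3 to compound 4 (0.01 log units; within the scatter) is expected to be small. Compound 4 is estimated at 8 uM in this assay, with a range from 2.5 uM to 25 uM, resting on compound 3 at 7.9 uM.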

Compound 4, concentration for 50% inhibition: 10 uM
For compound 4 the middle estimate is 1.3-fold (0.10 log units) below the measured one; low and high end bracket the measured number.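

In this assay the new step is a 1.3-fold higher number from compound 3 to compound 4 (0.10 log units; within the scatter), so on the core of compound 3 the change from benzyl to 4-chlorobenzyl gives two values that cannot be told apart. The same change on the core of compound 1 offers no size to set beside this one, because both ends of that step are caught by a limit of the assay and not by a number: the limit of > 40 uM in this assay, at which 2 of the 4 values shown sit. What the pair compound 3 and compound 4 shows therefore holds for one core only: there the chloro is carried without a change beyond the scatter, while nothing shows whether the step would keep this size on the core of compound 1.

Left open is whether another group on the same aromatic carbon, such as fluoro, methoxy, a nitrile or an amine, would move the number on the core of compound 3 beyond the scatter. Also open is what a carboxylic acid in place of the ethyl ester would do on the core of compound 1, where the compounds shown so far give only limits.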